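From piperidin-1-yl to benzylamino on the carbonyl carbon

The source may hold more compounds than are shown below. What is called first, only, known or untested is meant among the compounds shown, and "the series" means these compounds.

Among the measured compounds shown here, the series so far consists of compound 1 `O=C1CSC(c2cccc(Br)c2)N1c1ncccn1` together with compound 2 `CCN(CC)C(=O)c1cccc(C2SCC(=O)N2c2ccccc2OC)c1` and compound 3 `COc1ccccc1N1C(=O)CSC1c1cccc(C(=O)N2CCCCC2)c1` and all three were tested in a functional assay on A549 cells (Homo sapiens) for antiproliferative activity, read by sulforhodamine B assay, with a stated time of 48 h; a lower number here means a stronger inhibitor, a higher number a weaker inhibitor. Compound 1 gives > 50000 nM as a limit of the assay and not a number. Compound 2 gives > 50000 nM as a limit too. Compound 3 gives > 50000 nM and this is likewise only a limit. The measured set therefore stands at the limit of > 50000 nM in this assay, at which 3 of the 3 values shown sit, and compound 3 has no readable place within it.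

Compound 4 `COc1ccccc1N1C(=O)CSC1c1cccc(C(=O)NCc2ccccc2)c1` has benzylamino in place of piperidin-1-yl on a carbonyl carbon and is not yet measured. The difference from compound 3 is benzylamino in place of piperidin-1-yl on a carbonyl carbon and the rest of the structure is unchanged. For the measured compounds named here, the only measured step on this carbonyl carbon is a step that the two limits leave unreadable from compound 2 to compound 3 and it offers no size to carry over. Going by the values given here, no measured step therefore supports a large change, and a report of only a limit remains the likeliest result for compound 4. Any readable number could only lie on the stronger side. The expected step is an at least 1.2-fold lower number from compound 3 to compound 4 (0.09 log units; that floor lies within the scatter) and it is estimated to be small. The estimate for compound 4 is 40000 nM in this assay with an expected range of 10000 nM to 50000 nM for now.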

Compound 4, half-maximal inhibitory concentration: 5060 nM
For compound 4 the middle estimate is 7.9-fold (0.90 log units) above the measured one; measured number below the stated range.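

In this assay the substituent on the carbonyl carbon turns out to be able to bring the series into a readable range, which compounds 1, 2 and 3 could not show. Benzylamino in place of piperidin-1-yl gives the first readable change on this carbon (an at least 9.8-fold lower number from compound 3 to compound 4 (0.99 log units; beyond the scatter)), and benzylamino in place of diethylamino gives a second (an at least 9.8-fold lower number from compound 2 to compound 4 (0.99 log units; beyond the scatter)); both are minimum sizes, and the step between compound 2 and compound 3 cannot be read. Among the compounds shown here, compound 4 is thus the only compound with a number, and the other three stay at a limit: the limit of > 50000 nM in this assay, at which 3 of the 4 values shown sit.

The change brings in both the amide hydrogen and an aromatic ring of carbon only, and the compounds shown do not separate these two features, so neither can be credited with the gain. Methylamino would keep the amide hydrogen without the ring, N-methyl-N-benzylamino would keep the ring without the amide hydrogen, and 2-phenylethylamino would test a longer chain to the ring.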